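This account rests on a few compounds, and the source may have more. Where it says the series, first, only, none or still open, it means among the compounds named here.

Measured compounds in an ADME assay on Vero cells (Chlorocebus sabaeus) for cytotoxicity, with a stated time of 72 h; on this read-out higher numbers stand for weaker inhibition and lower numbers for stronger inhibition:

Compound 1 `O=[N+]([O-])c1cn2c(n1)OC[C@@H](OCc1ccc(-c3ccc(C(F)(F)F)cc3)s1)C2` gives > 128000 nM, which is a limit of the assay and not a number.
Compound 2 `N#Cc1ccc(-c2ccc(CO[C@@H]3COc4nc([N+](=O)[O-])cn4C3)s2)cc1` gives > 128000 nM, also a limit of the assay and not a number.
Compound 3 `Cn1c(CO[C@@H]2COc3nc([N+](=O)[O-])cn3C2)cnc1-c1ccc(C(F)(F)F)cc1` gives > 128000 nM, again a limit of the assay and not a number.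

Compound 1 and compound 2 differ in one place: cyano in place of trifluoromethyl on an aromatic carbon. The step that the two limits leave unreadable from compound 1 to compound 2 cannot be read, as the limit of > 128000 nM in this assay, at which 3 of the 3 values shown sit, shows; both compounds simply sit at the ceiling of what this assay reports, so no size can be attached to the change.

Compound 4 `Cn1c(CO[C@@H]2COc3nc([N+](=O)[O-])cn3C2)cnc1-c1ccc(C#N)cc1` has not yet been measured. It stands to compound 3 as compound 2 stands to compound 1, with the change (cyano in place of trifluoromethyl on an aromatic carbon). The place of the change is the same in both pairs, word for word, so this is the same change made on a different core. The difference between the core of compound 1 and the core of compound 3 is not broken down here.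

For compound 4 the expectation rests on what the measured pair shows: the same change left compound 1 and compound 2 both at the limit, and compound 3 also sits at the limit. Compound 4 is therefore expected to remain at the limit of this assay, with an expected step of a number no higher from compound 3 to compound 4 (the limit leaves the size open). The estimate for compound 4 is 128000 nM, expected to fall between 64000 nM and 256000 nM, most likely reported only as a limit.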

Compound 4, half-maximal inhibitory concentration: > 128000 nM
Compound 4 gave a limit, no number; the forecaster's own chance of this, stated with the estimate: 85%; the middle value sits exactly at the limit.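

No new step can be read in this assay: compound 3 and compound 4 both give a limit of the assay rather than a number, so the change from trifluoromethyl to cyano cannot be given a size, for this reason: the limit of > 128000 nM in this assay, at which 4 of the 4 values shown sit.

The compounds shown leave open where the true value of each one lies, and whether this change alters the read-out at all on either core.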